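This account rests on a few compounds, and the source may have more. Where it says the series, first, only, none or still open, it means among the compounds named here.

Measured so far in an assay for inhibition of Polyunsaturated fatty acid 5-lipoxygenase (Homo sapiens), read by spectrophotometry, tested at 10 uM, in the presence of a further agent that is not named here; on this read-out lower numbers stand for less inhibition and higher numbers for more inhibition at the one concentration tested (going by the name of the read-out):

compound 1 `Cc1nc(NC(=O)c2ccccc2)sc1C(=O)/C=C/c1ccccc1` — 73.5%
compound 2 `Cc1nc(NC(=O)c2ccc(F)cc2)sc1C(=O)/C=C/c1ccc(N(C)C)cc1` — 70.2%
compound 3 `Cc1nc(NC(=O)c2ccc(F)cc2)sc1C(=O)/C=C/c1ccco1` — 65.3%

Compound 1 holds the highest of the three numbers in this assay, but its gap to compound 2 and its gap to compound 3 are both within the usual scatter, so no order among the three can be read from these values. Within the data shown here, the only single-point step among the measured compounds is a number 4.9 percentage points lower from compound 2 to compound 3 (within the scatter), in which a six-membered carbon ring gives way to a five-membered aromatic ring with one hetero atom on the double-bonded chain carbon; the number hardly moved.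

Compound 4 `Cc1nc(NC(=O)c2ccccc2)sc1C(=O)/C=C/c1cccs1` differs from compound 1 as follows: thiophen-2-yl in place of phenyl on a double-bonded chain carbon bound to a double-bonded chain carbon. Among the measured compounds shown here, the leaving phenyl and the entering thiophen-2-yl sit at the same place on the double-bonded chain carbon as the groups exchanged between compound 2 and compound 3, so that step is the one relevant comparison. Because that comparison gave only a number 4.9 percentage points lower from compound 2 to compound 3 (within the scatter), compound 4 is expected to sit close to compound 1, with a step of a number 3.5 percentage points lower from compound 1 to compound 4 (within the scatter) that does not reach beyond the scatter. The estimate for compound 4 in this assay is 70%, with a range from 56% to 82%.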

Compound 4, a percentage reported as inhibition, at one concentration (the size of the read-out at that concentration, not a potency): 71.9%
For compound 4 the middle estimate is 1.9 percentage points below the measured one; the measured number falls inside the stated range.
By their numbers in this assay, from the lowest: compounds 3, 2, 4 and 1 (each within the scatter of the next).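

In this assay, among these compounds, the exchange of phenyl for thiophen-2-yl on a double-bonded chain carbon bound to a double-bonded chain carbon gives a number 1.6 percentage points lower from compound 1 to compound 4 (within the scatter) and is the first step at this place taken from an unsubstituted phenyl, with the rest of compound 1 kept. Unlike a number 4.9 percentage points lower from compound 2 to compound 3 (within the scatter), which pairs a substituted phenyl with an oxygen-containing ring, it shows that a five-membered aromatic ring with a sulfur atom can stand in for the plain six-membered carbon ring with no change beyond the scatter, so both ring exchanges at this place now lie within it. Nothing on hand gives a reason for this result.

All four compounds lie within the scatter of one another at a single concentration, so the series shows neither a group at this place that moves the number beyond the scatter nor how the compounds compare in potency. Open questions are whether a saturated ring such as cyclohexyl, a short alkyl chain, or a phenyl carrying a carboxylic acid would move the number at this place, and what the fluorine on the benzamide ring contributes on its own.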